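The source may hold more compounds than are shown below. What is called first, only, known or untested is meant among the compounds shown, and "the series" means these compounds.

Compound 1 `CCCCCCOc1ccc(C(O)C2OC(=O)c3c(OC)cc(OC)cc32)cc1` is the anchor of the series. In an ADME assay on RAW264.7 cells (Mus musculus) for cytotoxicity, read by MTT assay, with a stated time of 24 h, in the absence of a further agent (on this read-out lower numbers stand for stronger inhibition and higher numbers for weaker inhibition), compound 1 gives > 40000 nM, which is a limit of the assay and not a number. Compound 2 `COCCCOc1ccc(C(O)C2OC(=O)c3c(OC)cc(OC)cc32)cc1` gives > 40000 nM in this assay, again a limit. Compound 3 `COc1cc(OC)c2c(c1)C(C(O)c1ccc(OCc3ccc(C)cc3)cc1)OC2=O` likewise gives > 40000 nM in this assay, also a limit. The three measured steps, a step that the two limits leave unreadable from compound 1 to compound 2, a step that the two limits leave unreadable from compound 1 to compound 3 and a step that the two limits leave unreadable from compound 2 to compound 3, therefore give no readable size in either direction, and all that the measured set shows is the limit of > 40000 nM in this assay, at which 3 of the 3 values shown sit.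

Compound 4 `COc1cc(OC)c2c(c1)C(C(O)c1ccc(OCC3CCCCC3)cc1)OC2=O` is not yet measured. Against compound 1 it differs in one place: cyclohexyl in place of pentyl on a saturated chain carbon bound to an oxygen on an aromatic ring. Among the measured compounds shown here, the steps that bear on this change are those that also alter the group on the saturated chain carbon bound to an oxygen on the aromatic ring, a step that the two limits leave unreadable from compound 1 to compound 3 and a step that the two limits leave unreadable from compound 2 to compound 3, and both are unreadable from the limits. Nothing in the measured set points to a step beyond the scatter in this assay in either direction. Compound 4 is therefore expected to stand at the limit as well, with an estimated 45000 nM and a range from 20000 nM to 100000 nM. The expected step is a step that the limit leaves unreadable from compound 1 to compound 4, which is taken to lie within the scatter.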

Compound 4, half-maximal inhibitory concentration: > 40000 nM
Compound 4: only a limit was reported; the forecaster's own chance of this, stated with the estimate: 85%; the middle value lies beyond the limit too.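

Compound 4 gives > 40000 nM in this assay, which is a limit of the assay and not a number. Its steps to compound 1, compound 2 and compound 3 cannot be read. Compound 1, compound 2, compound 3 and compound 4 leave open whether any change on the saturated chain carbon bound to an oxygen on an aromatic ring alters the read-out, and the series offers only this: the limit of > 40000 nM in this assay, at which 4 of the 4 values shown sit.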